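Hydroxy on the Amide Nitrogen: Compound 3 to Compound 4

The source may report more compounds than this note shows. Statements on the series, on what has been measured and on what is new or still open speak of the compounds shown alone.

Compound 3 `Cc1nc(-c2ccc(C(F)(F)F)cc2)sc1CNc1ccc([C@H]2C[C@@H]2C(N)=O)cc1` gives 4.47 nM in a functional assay on CHO cells for agonist activity at Free fatty acid receptor 1 (Homo sapiens) (a higher number here means that more compound is needed for the effect, a lower number that less compound is needed), the lowest of the three numbers seen. Compound 2 `Cc1nc(-c2ccc(C(F)(F)F)cc2)sc1CNc1ccc(C(C)CC(=O)O)cc1` sits at 58.9 nM, and compound 1 `Cc1nc(-c2ccc(C(F)(F)F)cc2)sc1CNc1ccc(CC(C)C(=O)O)cc1` at 355 nM; the step of a 6.0-fold lower number from compound 1 to compound 2 (0.78 log units; beyond the scatter) and the step of a 13-fold lower number from compound 2 to compound 3 (1.12 log units; beyond the scatter) both changed the side chain that carries the acid or amide. Compound 4 `Cc1nc(-c2ccc(C(F)(F)F)cc2)sc1CNc1ccc([C@H]2C[C@@H]2C(=O)NO)cc1` differs from compound 3 only by hydroxy in place of hydrogen on an amide-type nitrogen. For the measured compounds named here, none of the measured steps touches this position, so they give no direct guide; the change is small and the amide group stays. The expectation for compound 4 is therefore a step of a 1.8-fold higher number from compound 3 to compound 4 (0.25 log units; within the scatter), close to no change beyond the scatter. Compound 4 is estimated at 8 nM, in a range from 2 nM to 40 nM.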

Compound 4, half-maximal effective concentration: 6.92 nM
Beside the measured number, compound 4's estimate is 1.2-fold (0.06 log units) above it, and the stated range covers the measured number.
By their numbers in this assay, from the lowest: compounds 3 and 4 (each within the scatter of the next); then compound 2; then compound 1.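

In this assay, for the compounds shown here, hydroxy can replace hydrogen on the amide-type nitrogen with no change beyond the scatter (a 1.5-fold higher number from compound 3 to compound 4 (0.19 log units; within the scatter)), something the earlier compounds could not show, since none varied this position. The 2-(hydroxycarbamoyl)cyclopropyl group also keeps the advantage over the two earlier side chains (an 8.5-fold lower number from compound 2 to compound 4 (0.93 log units; beyond the scatter); a 51-fold lower number from compound 1 to compound 4 (1.71 log units; beyond the scatter)). Nothing available explains why this change leaves the number within the scatter. Still open, going by these compounds, is whether a methoxy or an amino group on the same nitrogen would also stay within the scatter of compound 3.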